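The compounds below may be only part of what the source reports. "The series", "measured", "known", "first", "only" and "open" are said of these compounds alone.

Measured so far:
compound 1 `COc1cc(Cl)cc(-c2nn(-c3cccc(NC(=O)Nc4cc(C(F)(F)F)cc(C(F)(F)F)c4)c3)cc2-c2ccncc2)c1`: 46%
compound 2 `COc1cc(Cl)cc(-c2nn(-c3cccc(NC(=O)Nc4ccc(Cl)c(Cl)c4)c3)cc2-c2ccncc2)c1`: 87%

In a functional assay on SK-MEL-28 cells (Homo sapiens) for inhibition, read by sulforhodamine B assay, with a stated time of 48 h, tested at 1 uM (on this read-out higher numbers stand for a weaker effect at the one concentration tested and lower numbers for a stronger effect), compound 2 gives 87%, the higher of the two numbers and so the weaker effect of the pair; the nearest, compound 1, gives 46%, lower by a gap beyond the scatter. Compound 3 `COc1cc(Cl)cc(-c2nn(-c3cccc(NC(=O)Nc4cccc(C(F)(F)F)c4)c3)cc2-c2ccncc2)c1` has not been measured. It differs from compound 2 in one place: 3-(trifluoromethyl)phenyl in place of 3,4-dichlorophenyl on an amide-type nitrogen. Going by the values given here, no step between measured compounds exists for this change, so the expectation rests on the two values alone. In this assay a modest downward step, toward a stronger effect, is expected: a number 17 percentage points lower from compound 2 to compound 3 (beyond the scatter). Compound 3 is estimated at 70%, within 45% to 95%.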

Compound 3, a percentage reported as activity, at one concentration (the size of the read-out at that concentration, not a potency): 82%
Compound 3: the middle estimate sits 12 percentage points below what was measured; the measured number falls inside the stated range.
By their numbers in this assay, from the lowest: compound 1; then compounds 3 and 2 (each within the scatter of the next).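

On the amide-type nitrogen, 3-(trifluoromethyl)phenyl and 3,4-dichlorophenyl cannot be told apart in this assay: a number 5 percentage points lower from compound 2 to compound 3 (within the scatter). The large step comes instead with hydrogen in place of trifluoromethyl on an aromatic carbon: a number 36 percentage points higher from compound 1 to compound 3 (beyond the scatter), so among these compounds the stronger effect of compound 1 goes with that one group. Nothing available explains either step.

Still open, on these data alone, is whether a nitrile or a tert-butyl group in place of that trifluoromethyl would keep the stronger effect of compound 1. Also open, as far as these compounds go, is whether the same steps hold in other cell lines.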